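Isomeric Aryl Swap on a Urea-Bearing Core

The compounds below may be only part of what the source reports. "The series", "measured", "known", "first", "only" and "open" are said of these compounds alone.

Three compounds share one core that carries an aryl urea on one side and an arylamino group on the other. In a functional assay on NCI-H226 cells (Homo sapiens) for inhibition, read by MTT assay, with a stated time of 48 h, tested at 10 uM (on this read-out higher numbers stand for more inhibition at the one concentration tested (going by the name of the read-out) and lower numbers for less inhibition), compound 1 `Cc1ccc(Nc2cc(NC(=O)Nc3c(Cl)cccc3Cl)ncn2)cc1C` gives 41.3%, compound 2 `COc1cc(NC(=O)Nc2cc(Nc3cccc(C(C)(C)C)c3)ncn2)cc(OC)c1` gives 40% and compound 3 `COc1cc(NC(=O)Nc2cc(Nc3ccc(C)c(F)c3)ncn2)cc(OC)c1` gives 39.7%. Compound 1 has the highest of the three numbers, yet its gaps to compound 2 and compound 3 both lie within the scatter, so no order among them can be read. Among the compounds with values here, the one measured step, a number 0.3 percentage points lower from compound 2 to compound 3 (within the scatter), exchanged one arylamino group for another and left the read-out essentially unchanged.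

Compound 4 `CCc1ccc(Nc2cc(NC(=O)Nc3c(Cl)cccc3Cl)ncn2)cc1` differs from compound 1 by 4-ethylphenyl in place of 3,4-dimethylphenyl on a nitrogen on an aromatic ring. Within the data shown here, no measured step covers this exact exchange, but the only comparable exchange of an arylamino group, from compound 2 to compound 3, stayed within the scatter. The step from compound 1 to compound 4 is therefore expected to be a number 1.3 percentage points lower from compound 1 to compound 4 (within the scatter), none beyond the scatter. Compound 4 is accordingly estimated at 40%, within a range from 28% to 52%.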

Compound 4, a percentage reported as inhibition, at one concentration (the size of the read-out at that concentration, not a potency): 39.5%
Beside the measured number, compound 4's estimate is 0.5 percentage points above it; the range from low to high includes it.
By their numbers in this assay, from the lowest: compounds 4, 3, 2 and 1 (each within the scatter of the next).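

The exchange of (3,4-dimethylphenyl)amino for (4-ethylphenyl)amino, two groups with the same atoms joined differently, appears in this assay as a number 1.8 percentage points lower from compound 1 to compound 4 (within the scatter) and so gives no sign that this rearrangement of carbon atoms matters on this read-out. Unlike the earlier arylamino exchange, it was read on the aryl urea carried by compound 1, so both exchanges shown at this nitrogen, on two different aryl ureas, now stay within the scatter, and neither goes against that. Nothing shown explains why the read-out holds at this position.

On these data alone, whether a carboxylic acid or a dimethylamino group on this aromatic ring, or a chain longer than ethyl, would move the number beyond the scatter stays open. Every pair shown also holds the aryl group on the urea fixed, and its share in the read-out remains open.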